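The compounds below may be only part of what the source reports. "The series", "measured", "known", "first", "only" and "open" are said of these compounds alone.

Series notes, single-concentration read-out.

Compound 1 `Nc1ccccc1NC(=O)c1ccc(CSC(=S)N2CCN(c3ccc(Cl)cc3)CC2)cc1` gives 17.2% in a functional assay on MGC-803 cells (Homo sapiens) for antiproliferative activity, read by CCK-8 assay, with a stated time of 72 h, tested at 8 uM; on this read-out lower numbers stand for a weaker effect and higher numbers for a stronger effect at the one concentration tested. Compound 2 `N#Cc1ccc(N2CCN(C(=S)SCc3ccc(C(=O)Nc4ccccc4N)cc3)CC2)cc1` gives 37.6% in this assay. Within the data shown here, the only step measured so far is a number 20.4 percentage points higher from compound 1 to compound 2 (beyond the scatter), and on that basis compound 2 stands highest of the two numbers, with compound 1 as its nearest neighbour and that gap beyond the scatter.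

Compound 3 `Cc1ccc(N2CCN(C(=S)SCc3ccc(C(=O)Nc4ccccc4N)cc3)CC2)cc1` is the next member to be measured in this assay. It differs from compound 2 in one place: methyl in place of cyano on an aromatic carbon.

Among the measured compounds shown here, only one measured step bears on this change, and only loosely. The step from compound 1 to compound 2 swapped chloro for cyano at the same aromatic carbon and was modest though beyond the scatter. Methyl in place of cyano at that carbon has no measured counterpart in the series, so the direction can only be guessed from the fact that cyano sits at the top of the two numbers and chloro at the bottom; methyl is expected to fall back toward the level of compound 1. The expected step is therefore a number 15.6 percentage points lower from compound 2 to compound 3 (beyond the scatter), downward and of modest size, though with wide uncertainty.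

Compound 3 is expected to give about 22% in this assay, within a range of roughly 8% to 38%.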

Compound 3, a percentage reported as inhibition, at one concentration (the size of the read-out at that concentration, not a potency): 19.8%
Compound 3: middle estimate off by 2.2 percentage points, on the high side; measured number inside the range.
By their numbers in this assay, from the lowest: compounds 1 and 3 (each within the scatter of the next); then compound 2.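

With a third group at this aromatic carbon, para to a large group, the cyano compound is the one that stands apart in this assay: methyl in place of cyano gives a number 17.8 percentage points lower from compound 2 to compound 3 (beyond the scatter), a modest step beyond the scatter. Methyl in place of chloro gives a number 2.6 percentage points higher from compound 1 to compound 3 (within the scatter), so these two groups cannot be told apart here, and among the three groups shown, the gain seen on replacing chloro belongs to cyano alone. No measurement in hand explains why the nitrile differs from the other two groups.

The compounds shown leave open whether the higher number is particular to the nitrile, and an amine, a carboxylic acid or a methoxy group at this carbon would help to settle that. On these data alone, all three compounds carry their group at this one place and are compared at a single concentration, so it also remains open whether the lead of compound 2 holds across concentrations or with the nitrile elsewhere on the ring.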